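Substituting the amine nitrogen of compound 2

The source may report more compounds than this note shows. Statements on the series, on what has been measured and on what is new or still open speak of the compounds shown alone.

Measured in a functional assay on HepG2 cells (Homo sapiens) for inhibition, read by MTT assay, with a stated time of 48 h; on this read-out lower numbers stand for stronger inhibition and higher numbers for weaker inhibition:
- Compound 1 `CCOC(=O)C1=C(N/N=C(/Cl)c2ccc([N+](=O)[O-])cc2)Nc2[nH]nc(C)c2C1c1ccc(N(C)C)cc1`: 55500 nM
- Compound 2 `CCOC(=O)C1=C(N)Nc2[nH]nc(C)c2C1c1ccc(N(C)C)cc1`: 4240 nM

Compound 2 holds the lower of the two numbers in this assay. Compound 3 `CCOC(=O)C1=C(N/N=C(/C(C)=O)C(=O)OCC)Nc2[nH]nc(C)c2C1c1ccc(N(C)C)cc1` has not yet been measured, and the change leading to it is a group of 10 heavy atoms (6 carbon, 1 nitrogen, 3 oxygen; no ring) in place of a hydrogen atom, on an amine nitrogen. Among the compounds with values here, one measured step bears on this, also at an amine nitrogen, and it is large: a 13-fold lower number from compound 1 to compound 2 (1.12 log units; beyond the scatter). The group removed there is not the group entering here, so this is only a rough guide. A rise of similar or somewhat smaller size is expected, a 7.1-fold higher number from compound 2 to compound 3 (0.85 log units; beyond the scatter). The expected value for compound 3 is 30000 nM, within an estimated range of 9000 nM to 90000 nM.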

Compound 3, half-maximal inhibitory concentration: > 100000 nM
Compound 3 gave a limit, no number (the forecaster's own chance of this, stated with the estimate: 10%); middle value at least 3.3-fold (0.52 log units) away from the limit.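

In this assay the result for compound 3 is a limit and not a number: the limit of > 100000 nM in this assay, at which 1 of the 3 values shown sits. Even so, the ring-free group on the amine nitrogen brings an at least 23-fold higher number from compound 2 to compound 3 (1.37 log units; beyond the scatter), so a large rise at this position does not depend on the aromatic ring of the earlier substituent. The two substituents themselves are not separated, as the data give only an at least 1.8-fold higher number from compound 1 to compound 3 (0.25 log units; that floor lies within the scatter).

As far as these compounds go, it remains open whether a small group on this nitrogen, such as methyl or acetyl, would keep the number of compound 2. From the compounds shown here alone, how far compound 3 lies beyond its limit also remains open.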